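Replacing the methyl on the oxygen of compound 3

The source may hold more compounds than are shown below. What is called first, only, known or untested is meant among the compounds shown, and "the series" means these compounds.

Measured in a functional assay on HL-60 cells (Homo sapiens) for inhibition, read by MTT assay, with a stated time of 72 h (a lower number here means a stronger inhibitor, a higher number a weaker inhibitor), so far
Compound 1 `Cc1nc(-c2ccccc2)c(C(=O)N2CCN(c3cccc(Cl)c3)CC2)o1` gives 39.2 nM
Compound 2 `CC(=O)Nc1cccc(-c2nc(C)oc2C(=O)N2CCN(c3cccc(Cl)c3)CC2)c1` gives 208 nM
Compound 3 `COc1cccc(-c2nc(C)oc2C(=O)N2CCN(c3cccc(Cl)c3)CC2)c1` gives "not active" (no number reported)

Compound 3 offers no single number to start from: compound 3 is reported as "not active" (no number reported) in this assay and cannot be placed on the scale beside the other two. Compound 4 `Cc1nc(-c2cccc(OP(=O)(O)O)c2)c(C(=O)N2CCN(c3cccc(Cl)c3)CC2)o1` differs from it by a group of 4 heavy atoms (3 oxygen, 1 phosphorus; no ring) in place of one carbon atom, on an oxygen on an aromatic ring on an oxygen on an aromatic ring. Among the compounds with values here, only one measured step is available, acetamido in place of hydrogen on an aromatic carbon, which gave a 5.3-fold higher number from compound 1 to compound 2 (0.72 log units; beyond the scatter) as a modest loss beyond the scatter. Within the data shown here, that step does not measure the present change, and no step from compound 3 can be sized. With compound 2 at 208 nM as the nearest reference, a weaker inhibitor than compound 1 is the expectation, and a report without any number remains possible. Compound 4 is expected near 400 nM with an estimated range from 60 nM to 3000 nM in this read-out.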

Compound 4, half-maximal inhibitory concentration: > 1000 nM
Compound 4: no number, only a limit; the forecaster's own chance of this, stated with the estimate: 30%; at least 2.5-fold (0.39 log units) between middle value and limit.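

In this assay the reading for compound 4 is a limit of the assay and not a number: (the limit of > 1000 nM in this assay, at which 1 of the 4 values shown sits). Even so, the steps can be sized from below, with an at least 4.8-fold higher number from compound 2 to compound 4 (0.68 log units; beyond the scatter) and, against the core without any added group, an at least 25-fold higher number from compound 1 to compound 4 (1.40 log units; beyond the scatter). The earlier compounds shown here showed only that acetamido on this aromatic carbon still left a number on the scale, whereas the group holding phosphorus gives only a limit.

Steps from compound 3 cannot be read, as it has no number, so the swap of methyl on the oxygen remains unsized. From the compounds shown here alone, how far past its limit compound 4 lies also stays open, as does whether an amine or a carboxylic acid on the same aromatic carbon would give a number on this scale.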